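From Furan-3-yl to Thiophen-2-yl: Expected Potency

A few compounds are considered here, and "the series" means these few. Any claim that something is new, unique, unknown or untested is made for them only; others in the source may bear on it.

compound 1 `COc1ncnc2c1c(-c1ccsc1)cn2[C@@H]1O[C@H](CO)[C@@H](O)[C@H]1O`: 3450 nM
compound 2 `COc1ncnc2c1c(-c1ccoc1)cn2[C@@H]1O[C@H](CO)[C@@H](O)[C@H]1O`: 2820 nM

In a functional assay on K562 cells (Homo sapiens), read by MTT assay, with a stated time of 72 h (a lower number here means a stronger inhibitor, a higher number a weaker inhibitor), compound 1 gives 3450 nM and compound 2 gives 2820 nM. Compound 2 shows the lowest of these two numbers, yet the step of a 1.2-fold lower number from compound 1 to compound 2 (0.09 log units; within the scatter) lies within the scatter, so the two are not separated. Compound 3 `COc1ncnc2c1c(-c1cccs1)cn2[C@@H]1O[C@H](CO)[C@@H](O)[C@H]1O` differs from compound 2 by thiophen-2-yl in place of furan-3-yl on an aromatic carbon. Going by the values given here, the only measured step, a 1.2-fold lower number from compound 1 to compound 2 (0.09 log units; within the scatter), also exchanged one five-membered aromatic ring with 1 hetero atom for another and stayed within the scatter; thiophen-2-yl itself has no measured precedent here, so no step beyond the scatter is expected. Compound 3 is estimated at 3300 nM, range 1300 nM to 8500 nM, meaning an expected step of a 1.2-fold higher number from compound 2 to compound 3 (0.07 log units; within the scatter).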

Compound 3, half-maximal inhibitory concentration: 6200 nM
Compound 3: middle estimate off by 1.9-fold (0.27 log units), on the low side, and the stated range covers the measured number.
By their numbers in this assay, from the lowest: compounds 2, 1 and 3 (each within the scatter of the next, the first and the last beyond it).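

Going by these compounds alone, this position is not indifferent to which five-membered aromatic ring it carries: a 2.2-fold higher number from compound 2 to compound 3 (0.34 log units; beyond the scatter) is the first step in this set to pass the scatter, though only modestly. By contrast, a 1.8-fold higher number from compound 1 to compound 3 (0.25 log units; within the scatter) stays within the scatter, so the two thiophene attachments, thiophen-3-yl and thiophen-2-yl, cannot be told apart. No measurement here offers an explanation for the step.

All three compounds carry a five-membered aromatic ring with one hetero atom at this carbon. As far as these compounds go, how a phenyl ring, an amine or a short alkyl chain would fare there remains open.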